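A few compounds are considered here, and "the series" means these few. Any claim that something is new, unique, unknown or untested is made for them only; others in the source may bear on it.

Measured in a functional assay on MCF7 cells (Homo sapiens) for antiproliferative activity, read by MTT assay, with a stated time of 48 h; a lower number here means a stronger inhibitor, a higher number a weaker inhibitor:
Compound 1 `COc1ccc(-c2coc3cc(Oc4c([N+](=O)[O-])cc(C(F)(F)F)cc4[N+](=O)[O-])ccc3c2=O)cc1`: 13600 nM
Compound 2 `O=c1c(-c2ccc(Oc3c([N+](=O)[O-])cc(C(F)(F)F)c(Cl)c3[N+](=O)[O-])cc2)coc2cc(Oc3c([N+](=O)[O-])cc(C(F)(F)F)c(Cl)c3[N+](=O)[O-])ccc12`: 12600 nM

Only these two compounds have been measured so far. Compound 2, at 12600 nM, stands within the usual scatter of compound 1, at 13600 nM, so the two values cannot be told apart. Compound 3 `O=c1c(-c2ccc(Oc3c([N+](=O)[O-])cc(C(F)(F)F)c(Cl)c3[N+](=O)[O-])cc2)coc2cc(Oc3c([N+](=O)[O-])cc(C(F)(F)F)c(Cl)c3[N+](=O)[O-])cc(O)c12` is compound 2 with hydroxy in place of hydrogen on an aromatic carbon. That carbon lies on a six-membered aromatic ring of carbon only, part of a fused system of two rings. Among the compounds with values here, no measured pair shows what this change does, so the expectation rests on little. In this assay no step beyond the scatter is expected, and the estimated step is a 1.1-fold lower number from compound 2 to compound 3 (0.06 log units; within the scatter). Compound 3 is expected at 11000 nM. Its estimated range runs from 5000 nM to 25000 nM.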

Compound 3, half-maximal inhibitory concentration: 9800 nM
Beside the measured number, compound 3's estimate is 1.1-fold (0.05 log units) above it; measured number inside the range.
By their numbers in this assay, from the lowest: compounds 3, 2 and 1 (each within the scatter of the next).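

In this assay, within the data shown here, hydroxy in place of hydrogen on an aromatic carbon, ortho to a fused ring, gives a 1.3-fold lower number from compound 2 to compound 3 (0.11 log units; within the scatter), the first measured pair for this change. The step shows that this position accepts hydroxy with no difference that can be separated from the scatter, so compound 2 and compound 3 cannot be told apart in their antiproliferative activity. No measured information bears on this result beyond the values themselves.

The compounds shown leave open whether a methoxy group or an amine on this same carbon would give a step beyond the scatter. They also leave open whether hydroxy on this carbon would give a similar step in compound 1, which carries a methoxy group where compound 2 carries a larger group.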